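The compounds below may be only part of what the source reports. "The series", "measured", "known", "first", "only" and "open" are said of these compounds alone.

Of the compounds shown here, three built on one shared core have been tested in a functional assay on HL-60 cells (Homo sapiens) for cytotoxicity, read by MTT assay, with a stated time of 72 h; a higher number here means a weaker inhibitor, a lower number a stronger inhibitor. Compound 1 `Cc1ccc(S(=O)(=O)c2nc3ccccc3nc2Nc2ccc(N)cc2)cc1` gives 1220 nM in this assay. Compound 2 `Cc1ccc(S(=O)(=O)c2nc3ccccc3nc2Nc2cccc(N)c2)cc1` differs from compound 1 by 3-aminophenyl in place of 4-aminophenyl on a nitrogen on an aromatic ring; in this assay compound 2 gives 1080 nM, and the step is a 1.1-fold lower number from compound 1 to compound 2 (0.05 log units; within the scatter). Compound 3 `COc1ccc(S(=O)(=O)c2nc3ccccc3nc2Nc2ccc(N)cc2)cc1` differs from compound 1 by methoxy in place of methyl on an aromatic carbon; in this assay compound 3 gives 710 nM, the step being a 1.7-fold lower number from compound 1 to compound 3 (0.24 log units; within the scatter). All three values sit within the usual scatter of one another, so none can be called the stronger or weaker inhibitor.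

Compound 4 `COc1ccc(S(=O)(=O)c2nc3ccccc3nc2Nc2cccc(N)c2)cc1` has not yet been measured in this assay. It differs from compound 3 by 3-aminophenyl in place of 4-aminophenyl on a nitrogen on an aromatic ring, the same change that separates compound 2 from compound 1, now made on the core of compound 3, whose difference from the core of compound 1 was described above. Among the measured compounds shown here, the only guide to this change is the step of a 1.1-fold lower number from compound 1 to compound 2 (0.05 log units; within the scatter), and the step from compound 3 to compound 4 is expected to be similarly small, about a 1.1-fold lower number from compound 3 to compound 4 (0.04 log units; within the scatter). On that basis compound 4 is estimated to give 650 nM in this assay, most likely between 330 nM and 1300 nM, with the range kept wide since the expectation rests on a single earlier step.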

Compound 4, half-maximal inhibitory concentration: 1490 nM
Estimate against measurement, compound 4: 2.3-fold (0.36 log units) below, and the stated range ends below it.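

Moving the amine from 4-aminophenyl to 3-aminophenyl on the core of compound 3 gives a 2.1-fold higher number from compound 3 to compound 4 (0.32 log units; beyond the scatter), a modest step in this assay. This looks unlike the earlier step on the core of compound 1, but the gap between the two is no larger than two such steps can show by chance, so it does not establish that the core alters the effect of this change: the same change on two cores in this assay, a 1.1-fold lower number (0.05 log units; within the scatter) from compound 1 to compound 2 and a 2.1-fold higher number (0.32 log units; beyond the scatter) from compound 3 to compound 4, 2.4-fold (0.37 log units) apart, within the scatter of two such steps. The exchange of methyl for methoxy, read on the 3-aminophenyl compounds as a 1.4-fold higher number from compound 2 to compound 4 (0.14 log units; within the scatter), likewise gives no firm sign of depending on its partner group, though two pairs of compounds can neither prove that these changes carry over unchanged nor rule it out: the same change on two cores in this assay, a 1.7-fold lower number (0.24 log units; within the scatter) from compound 1 to compound 3 and a 1.4-fold higher number (0.14 log units; within the scatter) from compound 2 to compound 4, 2.4-fold (0.37 log units) apart, within the scatter of two such steps.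

Still open, going by these compounds, is whether a chlorine in place of the methoxy, or an amide or a carboxylic acid in place of the amine, would give steps that stand clear of the scatter. Such larger steps would test far better whether a change carries from one core to another.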